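Biaryl pyrrolidine amides: pyridin-2-yl for 2-methylphenyl

The source may hold more compounds than are shown below. What is called first, only, known or untested is meant among the compounds shown, and "the series" means these compounds.

The series is followed in an assay on HEK293 cells for inhibition of N-acylethanolamine-hydrolyzing acid amidase (Rattus norvegicus), read by LC-MS, with a stated time of 30 min; on this read-out higher numbers stand for weaker inhibition and lower numbers for stronger inhibition. Compound 1 `O=C(CCCCCCc1ccccc1F)N1CCCC1` gives 13700 nM in this assay. Compound 2 `O=C(CCCCCCc1ccc(F)cc1)N1CCCC1` gives 8000 nM in this assay. Compound 3 `Cc1ccccc1-c1ccc(CCC(=O)N2CCCC2)cc1` carries the biaryl on a shorter chain than compound 1 and compound 2. For compound 3 only a limit of the assay is reported, > 100000 nM. This is the limit described as the limit of > 100000 nM in this assay, at which 1 of the 3 values shown sits, so compound 3 stands at the weak end of what the assay can report, and no number for it is known.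

The next step keeps the core of compound 3 and changes the terminal ring: pyridin-2-yl in place of 2-methylphenyl on an aromatic carbon. The product is compound 4 `O=C(CCc1ccc(-c2ccccn2)cc1)N1CCCC1`, not yet measured in this assay.

Among the measured compounds shown here, no step between two measured compounds in this set changes one place only, so there is no measured step to lean on for this change. Because compound 3 sits at the limit > 100000 nM, any number for compound 4 can only be at or stronger than that limit. The step from compound 3 to compound 4 is expected to be small, toward stronger inhibition if anything, an at least 1.6-fold lower number from compound 3 to compound 4 (0.22 log units; that floor lies within the scatter). Compound 4 is expected to give about 60000 nM in this assay, in the range 15000 nM to 250000 nM, with a fair chance that again only a limit is reported.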

Compound 4, half-maximal inhibitory concentration: > 100000 nM
Compound 4 ended at the assay's limit; the forecaster's own chance of this, stated with the estimate: 50%; middle value at least 1.6-fold (0.22 log units) from the limit.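

Compound 3 and compound 4 both stand at a limit of this assay, not at a number, so no step can be read between them: the limit of > 100000 nM in this assay, at which 2 of the 4 values shown sit.

The compounds shown leave open whether pyridin-2-yl in place of 2-methylphenyl changes inhibition at all, and how far either compound lies from that limit.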